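This account rests on a few compounds, and the source may have more. Where it says the series, first, only, none or still open, it means among the compounds named here.

Compound 1 `COc1ccc2c(c1)CCCN2c1nc(C)nc2ccccc12`: 3.1 nM
Compound 2 `CSc1ccc(N(C)c2nc(C)nc3ccccc23)cc1`: 4.9 nM

In a functional assay on U-251 cells (Homo sapiens) for cytotoxicity, read by sulforhodamine B assay (on this read-out lower numbers stand for stronger inhibition and higher numbers for weaker inhibition), compound 1 and compound 2 lie within the scatter of each other, so the two numbers give no ranking. Compound 3 `COc1ccc2c(c1)CCCN2c1ncnc2ccccc12` is the core of compound 1 with hydrogen in place of methyl on an aromatic carbon, between two ring nitrogen atoms (hydrogen in place of methyl on an aromatic carbon). Within the data shown here, no measured pair covers this change, so the expectation is a judgement with little support from the data. A modest step toward weaker inhibition is expected, a 4.8-fold higher number from compound 1 to compound 3 (0.68 log units; beyond the scatter). Compound 3 is estimated at 15 nM, with an expected range of 4 nM to 60 nM.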

Compound 3, half-maximal inhibitory concentration: 27.8 nM
Beside the measured number, compound 3's estimate is 1.9-fold (0.27 log units) below it; the measured number falls inside the stated range.
By their numbers in this assay, from the lowest: compounds 1 and 2 (each within the scatter of the next); then compound 3.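

In this assay, replacing the methyl on the aromatic carbon, between two ring nitrogen atoms, with hydrogen gives a 9.0-fold higher number from compound 1 to compound 3 (0.95 log units; beyond the scatter). Among these compounds, this is the first single-place comparison, and it shows that this position is sensitive to the change, although compound 3 still gives 27.8 nM. Nothing available explains the step.

On these data alone, whether ethyl, trifluoromethyl or an amine at this carbon would match methyl remains open. So does whether hydrogen in place of methyl would produce a similar step on compound 2.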